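Hydrazinyl urea series: binding at the second sphingosine 1-phosphate receptor

A few compounds are considered here, and "the series" means these few. Any claim that something is new, unique, unknown or untested is made for them only; others in the source may bear on it.

Of the compounds shown here, three have numbers so far in an assay on isolated protein for binding affinity to sphingosine 1-phosphate receptor 2 (Homo sapiens), read by surface plasmon resonance; a higher number here means weaker binding, a lower number tighter binding. Compound 1 `Cc1c(Cc2ccccc2)c(NNC(=O)Nc2cc(Cl)nc(Cl)c2)nc2c1cnn2C` gives 870 nM. Compound 2 `Cc1nn(C)c2nc(NNC(=O)Nc3cc(Cl)nc(Cl)c3)cc(C3CC3)c12` gives 3650 nM, the highest of the three. Compound 3 `COc1ccc(-c2cc(NNC(=O)Nc3cc(Cl)nc(OC(C)C)c3)nc3c2cnn3C)cc1` gives 2320 nM, which lies within the scatter of compound 2, whereas compound 1 sits beyond the scatter at a lower number. Compound 4 `COc1ccc(-c2cc(NNC(=O)Nc3cc(Cl)nc(Cl)c3)nc3c2c(C)nn3C)cc1` is not yet measured; it differs from compound 2 by 4-methoxyphenyl in place of cyclopropyl on an aromatic carbon, a 4-methoxyphenyl in place of cyclopropyl on an aromatic carbon. Going by the values given here, no measured pair isolates this change. Since compound 3, which also carries the 4-methoxyphenyl, gives 2320 nM, a modest move toward a lower number in this assay is expected, a 2.3-fold lower number from compound 2 to compound 4 (0.36 log units; beyond the scatter), though it may stay within the scatter. Compound 4 is estimated at 1600 nM, range 500 nM to 5000 nM.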

Compound 4, dissociation constant: 1020 nM
Estimate against measurement, compound 4: 1.6-fold (0.20 log units) above; the measured number falls inside the stated range.
By their numbers in this assay, from the lowest: compounds 1 and 4 (each within the scatter of the next); then compounds 3 and 2 (each within the scatter of the next).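

In this assay, going by these compounds alone, 4-methoxyphenyl in place of cyclopropyl on the aromatic carbon opposite the ring nitrogen gives a 3.6-fold lower number from compound 2 to compound 4 (0.55 log units; beyond the scatter) and is the only single-place comparison so far. This position therefore holds the larger aryl group with tighter binding, at least on this core. Nothing available accounts for the shift.

On these data alone, whether the step belongs to the phenyl ring or to its methoxy remains open. A plain phenyl or a 4-aminophenyl on this carbon would separate the two.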